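The source may report more compounds than this note shows. Statements on the series, on what has been measured and on what is new or still open speak of the compounds shown alone.

Measured so far:
Compound 1 `N#CC1=C(N)Oc2c(N)cc3nc4ccccc4nc3c2C12C(=O)N(Cc1cnnn1-c1ccc([N+](=O)[O-])cc1)c1ccccc12` – in a functional assay on HCT-116 cells (Homo sapiens) for antiproliferative activity, read by MTT assay, with a stated time of 48 h (on this read-out higher numbers stand for weaker inhibition and lower numbers for stronger inhibition), compound 1 gives only a limit of the assay, > 50000 nM.
Compound 2 `CCc1cccc(CC)c1-n1nncc1CN1C(=O)C2(C(C#N)=C(N)Oc3c(N)cc4nc5ccccc5nc4c32)c2ccccc21` – in this assay compound 2 gives 37600 nM.

Within the data shown here, compound 2 holds the only actual number in this assay; the other entry is a limit, as the record the limit of > 50000 nM in this assay, at which 1 of the 2 values shown sits, notes. The step to compound 3 `N#CC1=C(N)Oc2c(N)cc3nc4ccccc4nc3c2C12C(=O)N(Cc1cnnn1-c1ccc(Cl)cc1Cl)c1ccccc12` is 2,4-dichlorophenyl in place of 2,6-diethylphenyl on an aromatic nitrogen. Among the measured compounds shown here, one measured step touches the same aromatic nitrogen: an at least 1.3-fold lower number from compound 1 to compound 2 (0.12 log units; that floor lies within the scatter), a change whose floor lies within the scatter and rests on a limit. Two different aryl groups on that aromatic nitrogen thus gave weak inhibition in both cases. Compound 3 is therefore expected to move by no more than the scatter, a step of a 1.1-fold higher number from compound 2 to compound 3 (0.03 log units; within the scatter). Compound 3 is estimated at 40000 nM, with a range from 15000 nM to 100000 nM, and a real chance that only a limit is reported.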

Compound 3, half-maximal inhibitory concentration: > 50000 nM
Compound 3 gave a limit, no number; the forecaster's own chance of this, stated with the estimate: 35%; middle value at least 1.2-fold (0.09 log units) from the limit.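

Compound 3 is a limit, not a number, and with it a third aryl group on the aromatic nitrogen joins the weak end of the series: the limit of > 50000 nM in this assay, at which 2 of the 3 values shown sit. In this assay, the change to 2,4-dichlorophenyl gives an at least 1.3-fold higher number from compound 2 to compound 3 (0.12 log units; that floor lies within the scatter), so this step has only a floor and does not separate the two aryl groups beyond the scatter. The step between compound 1 and compound 3 joins two limits and cannot be read.

Going by these compounds, all three compounds carry a six-membered aromatic ring of carbon only on that nitrogen, so it remains open whether a longer alkyl chain, or a group bearing an amine or a carboxylic acid, would change the read-out there. On these data alone, it is also open whether any change at this position can give a clearly lower number than compound 2 does.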